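Chain-end amine swap from compound 3 to compound 4

The source may report more compounds than this note shows. Statements on the series, on what has been measured and on what is new or still open speak of the compounds shown alone.

In a functional assay on A-375 cells (Homo sapiens) for cytotoxicity, read by MTT assay, with a stated time of 72 h (on this read-out higher numbers stand for weaker inhibition and lower numbers for stronger inhibition), compound 1 `O=C1c2c[n+]([O-])c3ccccc3c2C(=O)c2c1c1ccccc1n2Cc1cn(C[C@H](O)CO)nn1` gives 350 nM, compound 2 `O=C1c2c[n+]([O-])c3ccccc3c2C(=O)c2c1c1ccccc1n2CCCCN1CCCCC1` gives 190 nM, and compound 3 `CN(C)CCCCn1c2c(c3ccccc31)C(=O)c1c[n+]([O-])c3ccccc3c1C2=O` gives 470 nM. Two steps place compound 3 among its neighbours: a 1.3-fold higher number from compound 1 to compound 3 (0.13 log units; within the scatter) and a 2.5-fold higher number from compound 2 to compound 3 (0.39 log units; beyond the scatter).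

Compound 4 `CN1CCN(CCCCCn2c3c(c4ccccc42)C(=O)c2c[n+]([O-])c4ccccc4c2C3=O)CC1` keeps the shared core and alters the chain end: (4-methylpiperazin-1-yl)methyl in place of dimethylamino on a saturated chain carbon, four bonds along the chain from an aromatic nitrogen. Cut one bond further out, this reads 3-(dimethylamino)propyl to 4-(4-methylpiperazin-1-yl)butyl.

For the measured compounds named here, no measured compound carries the 4-methylpiperazin-1-yl group, so the evidence is indirect. Going by the values given here, the nearest precedent is compound 2, whose ring amine on the chain gives 190 nM. Among the compounds with values here, a modest move to a lower number in this assay is therefore expected, no larger than the step separating compound 2 from compound 3, and it may not clear the scatter. The expected step is a 1.8-fold lower number from compound 3 to compound 4 (0.26 log units; within the scatter). Compound 4 is estimated at 260 nM, with an expected range of 110 nM to 600 nM.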

Compound 4, half-maximal inhibitory concentration: 1710 nM
Compound 4: middle estimate off by 6.6-fold (0.82 log units), on the low side; measured number above the stated range.
By their numbers in this assay, from the lowest: compounds 2, 1 and 3 (each within the scatter of the next, the first and the last beyond it); then compound 4.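

In this assay, for the compounds shown here, a ring amine at the chain end does not by itself carry the low number of compound 2, since the change gives a 9.0-fold higher number from compound 2 to compound 4 (0.95 log units; beyond the scatter) and is the largest step so far. Against the open-chain amine the change gives a 3.6-fold higher number from compound 3 to compound 4 (0.56 log units; beyond the scatter) and against the triazole diol end it gives a 4.9-fold higher number from compound 1 to compound 4 (0.69 log units; beyond the scatter), which makes compound 4 the weakest of the four, with every step to it beyond the scatter. Nothing measured here accounts for these steps.

The 4-(4-methylpiperazin-1-yl)butyl group differs from 3-(piperidin-1-yl)propyl in both the amine and the chain, so the two remain unseparated; a 3-(4-methylpiperazin-1-yl)propyl or a 4-(piperidin-1-yl)butyl group would divide them. On these data alone, how a morpholin-4-yl chain end would read also stays open.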